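Replacing the carbamoyl-pyridyl arm with an acyclic amide

The source may hold more compounds than are shown below. What is called first, only, known or untested is meant among the compounds shown, and "the series" means these compounds.

Compound 1 `COc1ccc(-c2cc(C(=O)N(C)C)ccn2)cc1S(=O)(=O)Nc1cccc(NCCNC(=O)c2cccc(C)c2)c1`: 1810 nM
Compound 2 `COc1ccc(-c2cccc(C(=O)N(C)C)n2)cc1S(=O)(=O)Nc1cccc(NCCNC(=O)c2cccc(C)c2)c1`: 226 nM
Compound 3 `COc1ccc(-c2csc(C(=O)N(C)C)c2)cc1S(=O)(=O)Nc1cccc(NCCNC(=O)c2cccc(C)c2)c1`: 1330 nM

In a functional assay on CHO-RD-HGA16 cells for agonist activity at Orexin/Hypocretin receptor type 1 (Homo sapiens), read by fluorescence and calcium flux, with a stated time of 30 min (on this read-out higher numbers stand for an effect only at larger amounts of compound and lower numbers for an effect already at smaller amounts), compound 1 gives the highest number of the three measured compounds. Within the data shown here, the step of a 1.4-fold lower number from compound 1 to compound 3 (0.13 log units; within the scatter) stays within the scatter, whereas an 8.0-fold lower number from compound 1 to compound 2 (0.90 log units; beyond the scatter) is the only step beyond it. Compound 4 `COc1ccc(/C=C/C(=O)N(C)C)cc1S(=O)(=O)Nc1cccc(NCCNC(=O)c2cccc(C)c2)c1` differs from compound 1 by 2-(dimethylcarbamoyl)ethenyl in place of 4-(dimethylcarbamoyl)pyridin-2-yl on an aromatic carbon. Among the measured compounds shown here, no measured step removes the ring of this arm: the change to compound 2 moves the carbamoyl group within the same aromatic group, and the change to compound 3 exchanges one ring for another, so both bear on compound 4 only loosely. A step of at most modest size is therefore expected, with the direction open, and for compound 4 the number is estimated at 2500 nM, within 800 nM to 8000 nM, meaning a 1.4-fold higher number from compound 1 to compound 4 (0.14 log units; within the scatter).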

Compound 4, half-maximal effective concentration: > 10000 nM
Compound 4: only a limit was reported (the forecaster's own chance of this, stated with the estimate: 15%); middle value at least 4.0-fold (0.60 log units) away from the limit.
By their numbers in this assay, from the lowest: compound 2; then compounds 3 and 1 (each within the scatter of the next). At a limit, above all of these: compound 4.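

Compound 4 gives only a limit, not a number: the limit of > 10000 nM in this assay, at which 1 of the 4 values shown sits.
With the ring of this arm gone and 2-(dimethylcarbamoyl)ethenyl in its place, all three steps lie beyond the scatter: an at least 5.5-fold higher number from compound 1 to compound 4 (0.74 log units; beyond the scatter), an at least 7.5-fold higher number from compound 3 to compound 4 (0.87 log units; beyond the scatter) and an at least 44-fold higher number from compound 2 to compound 4 (1.64 log units; beyond the scatter). At this position, para to a methoxy group, the three ring-bearing arms all gave a measurable number, whereas the same amide on the open ethenyl chain does not.

As far as these compounds go, the full size of these steps remains open. Also open, from the compounds shown here alone, is whether a saturated ethyl chain, or a carboxylic acid in place of the dimethyl amide, would return a measurable number.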